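This account rests on a few compounds, and the source may have more. Where it says the series, first, only, none or still open, it means among the compounds named here.

Measured in an ADME assay on CCRF-CEM cells (Homo sapiens) for antiproliferative activity, with a stated time of 48 h; on this read-out higher numbers stand for weaker inhibition and lower numbers for stronger inhibition:
Compound 1, `Nc1ccc(/C=C/C(=O)c2ccccc2)cc1`, gives 34000 nM.
Compound 2, `COc1cccc(C(=O)/C=C/c2ccc(N)cc2)c1`, gives 26000 nM.
Compound 3, `COc1cccc(/C=C/C(=O)c2ccc(N)cc2)c1`, gives 23000 nM.

All three numbers sit close together. Compound 2 arises from compound 1 by methoxy in place of hydrogen on an aromatic carbon, and the step of a 1.3-fold lower number from compound 1 to compound 2 (0.12 log units; within the scatter). Compound 3 differs from compound 1 in more than one place, and the difference between the two cores is not broken down here; their two values lie close together.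

Compound 4, `COc1cc(/C=C/C(=O)c2ccc(N)cc2)cc(OC)c1`, has not yet been measured. It arises from compound 3 by methoxy in place of hydrogen on an aromatic carbon. This is the same kind of change as that from compound 1 to compound 2, though not the same: in compound 4 the new group is also meta to a methoxy group, which is not so in compound 2. Because the step of a 1.3-fold lower number from compound 1 to compound 2 (0.12 log units; within the scatter) stayed within the scatter, the second methoxy is expected to give a similarly small step, a 1.2-fold lower number from compound 3 to compound 4 (0.06 log units; within the scatter), in this assay. Compound 4 is therefore estimated at 20000 nM, with a likely range from 9000 nM to 45000 nM.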

Compound 4, half-maximal inhibitory concentration: 5700 nM
Compound 4: middle estimate off by 3.5-fold (0.55 log units), on the high side, and the stated range ends above it.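

In this assay, methoxy in place of hydrogen on an aromatic carbon gives a 4.0-fold lower number from compound 3 to compound 4 (0.61 log units; beyond the scatter) and so does not carry over at one fixed size from the core of compound 1 to the core of compound 3: the same change on two cores in this assay, a 1.3-fold lower number (0.12 log units; within the scatter) from compound 1 to compound 2 and a 4.0-fold lower number (0.61 log units; beyond the scatter) from compound 3 to compound 4, 3.1-fold (0.49 log units) apart, beyond the scatter of two such steps.

The two pairs also differ in the surroundings of the new group: in compound 4 it is meta to a methoxy group, which is not so in compound 2. Among the compounds shown here, with only two pairs, the data do not show whether the larger step belongs to the core, to this second methoxy, or to both, and they give no rule for how the change would behave on a further core.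

Open, going by these compounds, is whether the larger step needs a methoxy at all, or whether an ethoxy group or a chlorine atom in the same place would give a step of similar size. Also open, on these data alone, is what a second methoxy would do on the core of compound 2.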